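Swapping Benzyl for 4-Methylphenyl on an Amide Nitrogen

The compounds below may be only part of what the source reports. "The series", "measured", "known", "first", "only" and "open" are said of these compounds alone.

In a functional assay on G55T2 cells (Homo sapiens) for antiproliferative activity, read by WST assay, with a stated time of 72 h (a lower number here means a stronger inhibitor, a higher number a weaker inhibitor), compound 2 (`O=C(CCN(Cc1ccc(C(=O)NO)cc1)C(=O)c1ccccc1)NCc1ccccc1`) gives 5940 nM. That puts it in the middle of the three measured compounds: compound 1 (`Cc1ccc(NC(=O)CCN(Cc2ccc(C(=O)NO)cc2)C(=O)c2cc(C)cc(C)c2)cc1`) gives 370 nM, the lowest number, and compound 3 (`COc1cc(OC)cc(C(=O)N(CCC(=O)NCc2ccccc2)Cc2ccc(C(=O)NO)cc2)c1`) gives 14700 nM, the highest.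

Compound 4 (`Cc1ccc(NC(=O)CCN(Cc2ccc(C(=O)NO)cc2)C(=O)c2ccccc2)cc1`) has 4-methylphenyl in place of benzyl on an amide-type nitrogen. For the measured compounds named here, the only measured single change is a 2.5-fold higher number from compound 2 to compound 3 (0.39 log units; beyond the scatter), a modest step made at a different place in the molecule, so it offers little direct guidance for this swap. The closer clue is compound 1, which already carries the 4-methylphenyl group and gives 370 nM, although it also differs from compound 2 in a second place. A move toward a lower number in this assay therefore seems likely, covering only part of that gap. The expected change is a 5.0-fold lower number from compound 2 to compound 4 (0.69 log units; beyond the scatter). For compound 4, the estimated value is 1200 nM, with an expected range of 400 nM to 4000 nM.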

Compound 4, half-maximal inhibitory concentration: 540 nM
Beside the measured number, compound 4's estimate is 2.2-fold (0.35 log units) above it; the measured number falls inside the stated range.
By their numbers in this assay, from the lowest: compounds 1 and 4 (each within the scatter of the next); then compound 2; then compound 3.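

In this assay, the swap of benzyl for 4-methylphenyl on the amide-type nitrogen gives an 11-fold lower number from compound 2 to compound 4 (1.04 log units; beyond the scatter). This shows that the position carries a large effect, even though the two groups have the same count of heavy atoms and the same kind of aromatic ring. With 4-methylphenyl in place, replacing 3,5-dimethylphenyl with phenyl on the carbonyl carbon gives a 1.5-fold higher number from compound 1 to compound 4 (0.16 log units; within the scatter), so the low number of compound 1 does not depend on the 3,5-dimethylphenyl group, and no evidence on the cause of either result is available here.

A plain phenyl on that amide-type nitrogen would show how much of the large step rests on the methyl group of 4-methylphenyl. A 4-chlorophenyl group there would show whether another group can take the place of that methyl.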